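Diaminopyrimidine series: quinolinylmethyl in place of cyanobenzyl

The source may report more compounds than this note shows. Statements on the series, on what has been measured and on what is new or still open speak of the compounds shown alone.

Three compounds have numbers in an in vitro assay on CHOK cells for displacement of a labelled ligand from growth hormone secretagogue receptor type 1 (Homo sapiens); on this read-out higher numbers stand for weaker inhibition and lower numbers for stronger inhibition. Compound 1 `CCc1nc(N)nc(N)c1-c1ccc(NCc2ccc(S(C)(=O)=O)cc2)cc1` gives 7.4 nM in this assay. Compound 2 `CCc1nc(N)nc(N)c1-c1ccc(NCc2ccnc(Cl)c2)cc1` gives 110 nM in this assay, the highest number of the three. Compound 3 `N#Cc1ccc(CNc2ccc(-c3c(N)nc(N)nc3COCc3ccccc3)cc2)cc1` gives 2.8 nM in this assay, the lowest number of the three; its nearest neighbour is compound 1, and the gap between them lies beyond the usual scatter, while the gap to compound 2 is far larger. For the measured compounds named here, compound 1, compound 2 and compound 3 differ from one another in more than one place, so no single step between measured compounds can be read off.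

Compound 4 `Nc1nc(N)c(-c2ccc(NCc3cnc4ccccc4c3)cc2)c(COCc2ccccc2)n1` is not yet measured. It differs from compound 3 by quinolin-3-yl in place of 4-cyanophenyl on a saturated chain carbon bound to a nitrogen on an aromatic ring. Going by the values given here, no measured pair isolates this change. With compound 3 at 2.8 nM as the only anchor, the step from compound 3 to compound 4 is expected to be small, a 1.4-fold higher number from compound 3 to compound 4 (0.15 log units; within the scatter), without a clear direction beyond the scatter. Compound 4 is therefore estimated at 4 nM in this assay, within a range from 1.2 nM to 15 nM.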

Compound 4, half-maximal inhibitory concentration: 130 nM
Estimate against measurement, compound 4: 33-fold (1.51 log units) below, outside the stated range (above it).
By their numbers in this assay, from the lowest: compound 3; then compound 1; then compounds 2 and 4 (each within the scatter of the next).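

In this assay, for the compounds shown here, the place on a saturated chain carbon bound to a nitrogen on an aromatic ring proves sensitive: quinolin-3-yl in place of 4-cyanophenyl gives a 46-fold higher number from compound 3 to compound 4 (1.67 log units; beyond the scatter) as the first single-place step. This position therefore does not treat these two aromatic groups alike, although both carry no hydrogen-bond donors and the same count of hydrogen-bond acceptors. No measurement shown here bears on what lies behind this step.

The compounds shown leave open whether the step follows the loss of the nitrile or the arrival of the second ring; an unsubstituted benzyl and a naphthalen-2-ylmethyl at this place would separate the two. From the compounds shown here alone, whether the same change gives a step of similar size on the core of compound 1 also stays open.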